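A few compounds are considered here, and "the series" means these few. Any claim that something is new, unique, unknown or untested is made for them only; others in the source may bear on it.

Measured so far in a functional assay on UACC-62 cells (Homo sapiens) for antiproliferative activity, read by sulforhodamine B assay, with a stated time of 48 h; on this read-out higher numbers stand for weaker inhibition of growth and lower numbers for stronger inhibition of growth:
- compound 1, `Cc1nc(SCC(=O)Nc2nc(-c3ccc(Cl)cc3)cs2)n(Nc2ccccc2)c1C`: 3090 nM
- compound 2, `Cc1ccc(Nn2c(SCC(=O)Nc3nc(-c4ccccc4)cs3)nc(C)c2C)cc1`: 3150 nM

Compound 1 and compound 2 return numbers that sit within the scatter of each other in this assay; nothing separates the two, and no ordering of them can be read from these figures. Among the compounds with values here, both carry the same shared core and differ in the aryl group on the thiazole and in the substituent on the anilino ring, with no single-change step between them recorded.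

Compound 3, `COc1ccc(Nn2c(SCC(=O)Nc3nc(-c4ccc(Cl)cc4)cs3)nc(C)c2C)cc1`, has not been measured in this assay. It differs from compound 1 by methoxy in place of hydrogen on an aromatic carbon. Compound 2, which carries a small group at the same place as compound 3, gives a number in the same range as compound 1, so little movement is expected. The estimated step of a 1.0-fold lower number from compound 1 to compound 3 (0.01 log units; within the scatter) is taken as none beyond the scatter. Compound 3 is expected at 3000 nM, with a range from 1200 nM to 7500 nM.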

Compound 3, concentration for 50% growth inhibition: 3620 nM
Compound 3: middle estimate off by 1.2-fold (0.08 log units), on the low side; the measured number falls inside the stated range.
By their numbers in this assay, from the lowest: compounds 1, 2 and 3 (each within the scatter of the next).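

Read in this assay, the change from anilino to (4-methoxyphenyl)amino gives the first single-change step in this set (a 1.2-fold higher number from compound 1 to compound 3 (0.07 log units; within the scatter)). On this evidence, the aromatic carbon para to a large group tolerates methoxy in place of hydrogen, and compound 1 and compound 3 cannot be separated on this read-out. No measurement shown here offers a reason for this result.

One substituent cannot define the scope of this position, so an amine, a carboxylic acid or a longer alkoxy chain on the same carbon could still give a clearly different number. Compound 2 differs from compound 1 in two places, which leaves the separate contributions of its methyl group and of the chloro group on compound 1 unresolved.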